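The source may report more compounds than this note shows. Statements on the series, on what has been measured and on what is new or still open speak of the compounds shown alone.

Measured so far in a functional assay on Vero cells (Chlorocebus sabaeus) for inhibition; a higher number here means a weaker inhibitor, a lower number a stronger inhibitor:

- compound 1 `COc1cc(/C=C/C(=O)c2cccc(NC(=O)c3c(Cl)cccc3Cl)c2)ccc1O`: 2.48 ug/mL
- compound 2 `COc1cc(/C=C/C(=O)c2cccc(NC(=O)c3cccs3)c2)ccc1O`: 3.98 ug/mL
- compound 3 `COc1cc(/C=C/C(=O)c2cccc(NC(=O)c3cc(Cl)cc(Cl)c3)c2)ccc1O`: > 50 ug/mL (a limit, not a number)

Compound 3 is known only through a limit, (the limit of > 50 ug/mL in this assay, at which 1 of the 3 values shown sits), so its true value is not pinned down. Compound 4 `COc1cc(/C=C/C(=O)c2cccc(NC(=O)c3ccco3)c2)ccc1O` has not been measured in this assay and differs from compound 3 in one place: furan-2-yl in place of 3,5-dichlorophenyl on a carbonyl carbon. In words, it carries furan-2-yl in place of 3,5-dichlorophenyl on a carbonyl carbon.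

For the measured compounds named here, three measured steps bear on this change. Replacing other groups with 3,5-dichlorophenyl was costly both times: an at least 20-fold higher number from compound 1 to compound 3 (1.30 log units; beyond the scatter) and an at least 12-fold higher number from compound 2 to compound 3 (1.09 log units; beyond the scatter) are large steps toward a weaker inhibitor. The two remaining groups sit close together, as a 1.6-fold higher number from compound 1 to compound 2 (0.21 log units; within the scatter) lies within the scatter. Leaving 3,5-dichlorophenyl behind should therefore give a large step toward a lower number. The best guide is compound 2 at 3.98 ug/mL, whose thiophen-2-yl is the nearest measured match to furan-2-yl. Going by the values given here, the expected change is an at least 10-fold lower number from compound 3 to compound 4 (1.00 log units; beyond the scatter), an estimate resting on only three compounds. Compound 4 is estimated at 5 ug/mL, with an expected range from 1.5 ug/mL to 25 ug/mL.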

Compound 4, half-maximal inhibitory concentration: 3.11 ug/mL
For compound 4 the middle estimate is 1.6-fold (0.21 log units) above the measured one; measured number inside the range.
By their numbers in this assay, from the lowest: compounds 1, 4 and 2 (each within the scatter of the next). At a limit, above all of these: compound 3.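

In this assay, furan-2-yl on this carbonyl carbon lands level with the two groups already known to work here: the swap from thiophen-2-yl gives a 1.3-fold lower number from compound 2 to compound 4 (0.11 log units; within the scatter), and the swap from 2,6-dichlorophenyl gives a 1.3-fold higher number from compound 1 to compound 4 (0.10 log units; within the scatter). Three different groups now agree at this position, leaving 3,5-dichlorophenyl as the lone outlier among the four, and moving away from it to a five-membered aromatic ring with an oxygen as its hetero atom gives an at least 16-fold lower number from compound 3 to compound 4 (1.20 log units; beyond the scatter). That step has a floor but no known full size, since compound 3 is held only by a limit: the limit of > 50 ug/mL in this assay, at which 1 of the 4 values shown sits.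

The four compounds do not show how far this tolerance reaches beyond aromatic rings, for example to a plain methyl, a longer alkyl chain, or a ring carrying an amine or a carboxylic acid. They also leave open whether the loss seen with 3,5-dichlorophenyl needs both chlorines, a question that a phenyl ring with one chlorine or none could help to settle.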